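Chloro to trifluoromethyl on the fused ring of compound 1

The source may report more compounds than this note shows. Statements on the series, on what has been measured and on what is new or still open speak of the compounds shown alone.

Measured so far:
compound 1 `CC(C(=O)O)c1nn(Cc2cn3cc(OCC4CC4)c(Cl)cc3n2)c2ccccc2c1=O` — 15 nM
compound 2 `COC(C(=O)O)c1nn(Cc2cn3cc(OCC4CC4)c(Cl)cc3n2)c2ccccc2c1=O` — 217 nM

In a functional assay on HFL1 cells for antagonist activity at sphingosine 1-phosphate receptor 2 (Homo sapiens), read by ELISA, with a stated time of 24 h, in the presence of a further agent that is not named here (a lower number here means a stronger inhibitor, a higher number a weaker inhibitor), compound 1 gives 15 nM, the lowest of the two numbers shown. For the measured compounds named here, compound 2 is the only neighbour, and the step from compound 1 to compound 2 is a 14-fold higher number from compound 1 to compound 2 (1.16 log units; beyond the scatter); that step concerns the saturated chain carbon, not the fused ring.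

Compound 3 `CC(C(=O)O)c1nn(Cc2cn3cc(OCC4CC4)c(C(F)(F)F)cc3n2)c2ccccc2c1=O` differs from compound 1 by trifluoromethyl in place of chloro on an aromatic carbon. Going by the values given here, no measured step touches this position, so nothing speaks directly to the size of this change, and the single measured step cannot be read across to it. Among the compounds with values here, with no bearing step, the working expectation for compound 3 is a number close to that of compound 1 in this assay, with no step beyond the scatter, which is expressed as a 1.3-fold higher number from compound 1 to compound 3 (0.12 log units; within the scatter). On that basis compound 3 is estimated at 20 nM in this assay, within a range of 6 nM to 70 nM.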

Compound 3, half-maximal inhibitory concentration: 56 nM
The estimate for compound 3 lay 2.8-fold (0.45 log units) below the measured number, within the range that was stated.
By their numbers in this assay, from the lowest: compound 1; then compound 3; then compound 2.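

The position on the six-membered aromatic ring, ortho to the cyclopropylmethoxy group, is sensitive to the group it carries: in this assay, trifluoromethyl in place of chloro gives a 3.7-fold higher number from compound 1 to compound 3 (0.57 log units; beyond the scatter). Of the two groups seen here, chloro therefore gives the lower number, although this step is smaller than a 14-fold higher number from compound 1 to compound 2 (1.16 log units; beyond the scatter) at the saturated chain carbon. Nothing available explains the difference between chloro and trifluoromethyl at this position.

The compounds shown leave open how a fluoro, methyl, nitrile or methoxy group would read at this position in this assay, so two groups do not yet define a trend there. Also open, from the compounds shown here alone, is whether trifluoromethyl would give a step of similar size on the methoxy-bearing chain of compound 2.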